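A few compounds are considered here, and "the series" means these few. Any claim that something is new, unique, unknown or untested is made for them only; others in the source may bear on it.

Measured compounds:
- compound 1, `COc1ccc(C(=O)/C=C/c2cc3ccccc3[nH]c2=O)cc1`: in a functional assay on MDA-MB-231 cells (Homo sapiens) for cytotoxicity, read by sulforhodamine B assay, with a stated time of 24 h (a higher number here means a weaker inhibitor of growth, a lower number a stronger inhibitor of growth), compound 1 gives 17900 nM
- compound 2, `O=C(/C=C/c1cc2ccccc2[nH]c1=O)c1ccc(O)cc1`: in this assay compound 2 gives 15000 nM

Among the measured compounds shown here, compound 2 holds the lower of the two numbers, with compound 1 nearest to it; the single measured step, a 1.2-fold lower number from compound 1 to compound 2 (0.08 log units; within the scatter), is within the scatter, so neither compound can be set above the other.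

The next compound is compound 3, `O=C(/C=C/c1cc2ccccc2[nH]c1=O)c1ccc(Cl)cc1`. Relative to compound 2 the change is chloro in place of hydroxy on an aromatic carbon.

For the measured compounds named here, no measured step involves a chloro group, and the only step available, a 1.2-fold lower number from compound 1 to compound 2 (0.08 log units; within the scatter), concerns a methyl taken off an oxygen on the same ring and stayed within the scatter. The data give no ground for a shift beyond the scatter in either direction in this assay. Compound 3 is therefore expected to lie near compound 2, at an estimated 15000 nM, with a range from 5000 nM to 45000 nM; the step that this estimate means is no change at the digits printed from compound 2 to compound 3 (within the scatter).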

Compound 3, concentration for total growth inhibition: 28300 nM
The estimate for compound 3 lay 1.9-fold (0.28 log units) below the measured number; the range from low to high includes it.
By their numbers in this assay, from the lowest: compounds 2, 1 and 3 (each within the scatter of the next).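

In this assay swapping the hydroxy for chloro on this aromatic carbon, para to a large group, gives a 1.9-fold higher number from compound 2 to compound 3 (0.28 log units; within the scatter) and chloro in place of methoxy gives a 1.6-fold higher number from compound 1 to compound 3 (0.20 log units; within the scatter) in the same series. Both steps lie within the scatter, so the position now shows no separation among hydroxy, methoxy and chloro, even though the step from compound 2 to compound 3 removes the hydroxy hydrogen-bond donor and acceptor and adds neither back. No measured evidence bears on these numbers.

Still open, on these data alone, is whether any other group at this position gives a step beyond the scatter, for example an amine, a carboxylic acid or a longer chain such as butoxy. As far as these compounds go, all three compounds keep the shared core, so the effect of changes elsewhere in the structure also remains open.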